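The source may report more compounds than this note shows. Statements on the series, on what has been measured and on what is new or still open speak of the compounds shown alone.

Notes on the series. All three measured compounds share one core and differ only in the group on the carbonyl carbon. Compound 1 `CCN(CC)S(=O)(=O)c1ccc(S(=O)(=O)N2CCC[C@@H](C(=O)NC3CN(C(=O)OC(C)(C)C)C3)C2)cc1`, compound 2 `CCN(CC)S(=O)(=O)c1ccc(S(=O)(=O)N2CCC[C@@H](C(=O)N3CCN(c4nc(C)no4)CC3)C2)cc1` and compound 3 `CCN(CC)S(=O)(=O)c1ccc(S(=O)(=O)N2CCC[C@@H](C(=O)NC3COC3)C2)cc1` were run in a functional assay on MIA PaCa-2 cells (Homo sapiens) for inhibition, read by MTT assay, with a stated time of 7 days; a lower number here means a stronger inhibitor, a higher number a weaker inhibitor. Compound 1 gives 200 nM, compound 2 gives 250 nM and compound 3 gives 2300 nM. Compound 2 stands second highest of the three numbers; its nearest neighbour follows from a 1.3-fold higher number from compound 1 to compound 2 (0.10 log units; within the scatter) and its furthest from a 9.2-fold higher number from compound 2 to compound 3 (0.96 log units; beyond the scatter). The remaining step, a 12-fold higher number from compound 1 to compound 3 (1.06 log units; beyond the scatter), shows the same gap from the other end.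

Compound 4 `CCN(CC)S(=O)(=O)c1ccc(S(=O)(=O)N2CCC[C@@H](C(=O)N3CCN(c4nnc(C(C)C)o4)CC3)C2)cc1` is compound 2 with a change confined to the aromatic ring on the six-membered non-aromatic ring with 2 nitrogen: 5-isopropyl-1,3,4-oxadiazol-2-yl in place of 3-methyl-1,2,4-oxadiazol-5-yl on an amine nitrogen in a ring. Within the data shown here, no measured step alters that ring. Among the measured compounds shown here, the steps that bear on it are a 1.3-fold higher number from compound 1 to compound 2 (0.10 log units; within the scatter), where two quite different groups on the carbonyl carbon give numbers within the scatter, and a 9.2-fold higher number from compound 2 to compound 3 (0.96 log units; beyond the scatter), where the loss appears only once the whole 4-(3-methyl-1,2,4-oxadiazol-5-yl)piperazin-1-yl is replaced by a much smaller group. Compound 4 keeps that larger assembly, so no step beyond the scatter is expected in this assay, no change at the digits printed from compound 2 to compound 4 (within the scatter). Compound 4 is therefore estimated at 250 nM, with a range of 120 nM to 600 nM.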

Compound 4, half-maximal inhibitory concentration: 1800 nM
Beside the measured number, compound 4's estimate is 7.2-fold (0.86 log units) below it, and the stated range ends below it.
By their numbers in this assay, from the lowest: compounds 1 and 2 (each within the scatter of the next); then compounds 4 and 3 (each within the scatter of the next).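

The aromatic ring on an amine nitrogen in a ring is not a silent part of the larger assembly: a 7.2-fold higher number from compound 2 to compound 4 (0.86 log units; beyond the scatter) in this assay is a step beyond the scatter from a change confined to that ring, whereas the earlier loss, a 9.2-fold higher number from compound 2 to compound 3 (0.96 log units; beyond the scatter), came with replacement of the whole 4-(3-methyl-1,2,4-oxadiazol-5-yl)piperazin-1-yl. The step joins two changes, since the ring goes from 1,2,4-oxadiazole to 1,3,4-oxadiazole and the substituent from methyl to isopropyl, while the heavy-atom count rises from 6 to 8 and the hydrogen-bond donor and acceptor counts stay the same. No measurement on these compounds speaks to what lies behind the step.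

Going by these compounds, the share of each change stays open: 5-methyl-1,3,4-oxadiazol-2-yl and 3-isopropyl-1,2,4-oxadiazol-5-yl on the same nitrogen would separate the ring arrangement from the substituent. Also open, on these data alone, is how a chain or ring on the 1,3,4-oxadiazole other than isopropyl, such as ethyl or cyclopropyl, would read in this assay.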